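Methyl-to-hydrogen change on an aromatic oxygen: cytotoxicity notes

The source may hold more compounds than are shown below. What is called first, only, known or untested is meant among the compounds shown, and "the series" means these compounds.

The series comprises compound 1 `COc1cc(/C=C/C(=O)OCCCO[N+](=O)[O-])ccc1OCCCO[N+](=O)[O-]`, compound 2 `O=C(/C=C/c1ccc(OCCCCCCO[N+](=O)[O-])c(O)c1)OCCCCCCO[N+](=O)[O-]`, compound 3 `COc1cc(/C=C/C(=O)OCCCCCCO[N+](=O)[O-])ccc1OCCCCCCO[N+](=O)[O-]` and the as yet unmeasured compound 4 `O=C(/C=C/c1ccc(OCCCO[N+](=O)[O-])c(O)c1)OCCCO[N+](=O)[O-]`. All four were or are to be read in a functional assay on LOX IMVI cells (Homo sapiens) for cytotoxicity, read by resazurin assay, with a stated time of 72 h; on this read-out higher numbers stand for weaker inhibition and lower numbers for stronger inhibition.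

In this assay compound 1 gives > 50000 nM, which is a limit of the assay and not a number. Compound 2 gives > 50000 nM, likewise a limit. Compound 3 gives > 50000 nM, again a limit.

Between compound 3 and compound 2 the only change is hydrogen in place of methyl on an oxygen on an aromatic ring. The corresponding step, a step that the two limits leave unreadable from compound 3 to compound 2, cannot be sized, because of the limit of > 50000 nM in this assay, at which 3 of the 3 values shown sit.

The difference between the core of compound 1 and the core of compound 3 is not broken down here. Compound 4 is reached from compound 1 by hydrogen in place of methyl on an oxygen on an aromatic ring, and since the place of this change is described in the same words as that of the change from compound 3 to compound 2, it is the same change made on a different core.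

The step from compound 1 to compound 4 is expected to be a step that the limit leaves unreadable from compound 1 to compound 4; this expectation rests on the unreadable step that the two limits leave unreadable from compound 3 to compound 2 and on the fact that compound 1 already sits at > 50000 nM, where (the limit of > 50000 nM in this assay, at which 3 of the 3 values shown sit). Compound 4 is therefore estimated at 60000 nM, within a range from 30000 nM to 150000 nM, with a limit rather than a number the most likely outcome.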

Compound 4, half-maximal inhibitory concentration: 6940 nM
Estimate against measurement, compound 4: 8.6-fold (0.94 log units) above; the measured number lies below the stated range.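

In this assay, the methoxy to hydroxy change on the core of compound 1 gives an at least 7.2-fold lower number from compound 1 to compound 4 (0.85 log units; beyond the scatter). The same change on the core of compound 3 gives a step that cannot be read, so the data neither confirm nor refute that the effect carries from one core to the other: the limit of > 50000 nM in this assay, at which 3 of the 4 values shown sit. Compound 2, the hydroxy partner on that second core, gives > 50000 nM, which is a limit of the assay and not a number, so the lower number from this change is shown on the core of compound 1 only and not as a rule for the series.

Open, as far as these compounds go, is whether an amine or a carboxylic acid in place of the hydroxy on the core of compound 1 would also give a number in this assay, or whether that outcome is particular to the hydroxy of compound 4. Among the compounds shown here, also open is how the methoxy to hydroxy change reads on a longer chain than the one in compound 2, where a step of readable size might allow the two cores to be compared.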